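The source may hold more compounds than are shown below. What is called first, only, known or untested is meant among the compounds shown, and "the series" means these compounds.

Measured so far in an assay on Cerebral cortex for displacement of a labelled ligand from adenosine receptor A1 (Bos taurus); a lower number here means a stronger inhibitor, a higher number a weaker inhibitor: compound 1 `CCCNc1nc(-c2ccccc2)nc2c1nnn2Cc1ccccc1` gives 37 nM; compound 2 `CCCCCCNc1nc(-c2ccccc2)nc2c1nnn2Cc1ccccc1` gives 13.2 nM; compound 3 `CCCCCCNc1nc(-c2ccccc2)nc2c1nnn2Cc1ccccc1C(F)(F)F` gives "not determined" (no result reported), so no number is available for it in this assay.

Within the data shown here, compound 2 holds the lowest number of the two available, with compound 1 as its only neighbour. Among the measured compounds shown here, the single measured step, a 2.8-fold lower number from compound 1 to compound 2 (0.45 log units; beyond the scatter), shows that lengthening the chain on the ring nitrogen lowers the number by a modest margin.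

Compound 4 `OCCNc1nc(-c2ccccc2)nc2c1nnn2Cc1ccccc1` is reached from compound 2 by hydroxy in place of butyl on a saturated chain carbon, two bonds along the chain from a nitrogen on an aromatic ring. For the measured compounds named here, only the step from compound 1 to compound 2 bears on this, and it runs in the opposite sense: here the chain is cut back well below the length of compound 1, and a hydroxy enters, a group for which no comparison exists within the set. Going by the values given here, the expectation is therefore a higher number than compound 2 shows, beyond the scatter, with wide uncertainty because the hydroxy has no precedent here. The expected step is an 11-fold higher number from compound 2 to compound 4 (1.06 log units; beyond the scatter). Compound 4 is estimated at 150 nM, within a range from 40 nM to 600 nM.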

Compound 4, inhibition constant: 38 nM
For compound 4 the middle estimate is 3.9-fold (0.60 log units) above the measured one; measured number outside the range, below it.
By their numbers in this assay, from the lowest: compound 2; then compounds 1 and 4 (each within the scatter of the next).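

In this assay, the change from hexylamino to (2-hydroxyethyl)amino gives a 2.9-fold higher number from compound 2 to compound 4 (0.46 log units; beyond the scatter), so the hexyl chain of compound 2 keeps a modest lead over this short hydroxy-bearing chain. Hydroxy in place of methyl at the same place gives a 1.0-fold higher number from compound 1 to compound 4 (0.01 log units; within the scatter), which shows that in this assay a terminal hydroxy on this chain is tolerated as well as the terminal methyl of the propyl chain, with no order between the two compounds. No supporting measurement bears on the reason for either step.

On these data alone, whether a hydroxy at the end of a longer chain, such as 6-hydroxyhexyl, would retain the lead of the hexyl chain remains open. Also open, as far as these compounds go, is how an amine or a carboxylic acid would compare with the hydroxy at this place.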